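A new group on the carbonyl carbon

The source may report more compounds than this note shows. Statements on the series, on what has been measured and on what is new or still open speak of the compounds shown alone.

Compound 1 `O=C(NCc1cccc(Cn2cnc3ccccc32)c1)c1cc(Br)c[nH]1`: 32%
Compound 2 `O=C(NCc1cccc(Cn2cnc3ccccc32)c1)c1cc2ccccc2[nH]1`: 65%

For the measured compounds named here, in an ADME assay on microsomes from liver (Mus musculus, strain CD-1) for metabolic stability, read by LC-MS, using NADPH, with a stated time of 1 h, tested at 50 uM (a lower number here means that less of the compound is left, a higher number that more of the compound is left), compound 2 gives 65%, the highest of the two numbers so far. Compound 3 `N#Cc1ccc(C(=O)NCc2cccc(Cn3cnc4ccccc43)c2)cc1` carries 4-cyanophenyl in place of 1H-indol-2-yl on a carbonyl carbon. Going by the values given here, the only measured step at this place is a number 33 percentage points higher from compound 1 to compound 2 (beyond the scatter). Among the compounds with values here, that single step shows that this place can matter, but 4-cyanophenyl itself has no measurement yet. A smaller, downward move is therefore expected, starting from the higher of the two numbers: a number 15 percentage points lower from compound 2 to compound 3 (beyond the scatter). The estimate for compound 3 is 50%, with an expected range of 25% to 75%.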

Compound 3, percent of the compound remaining: 59%
Compound 3: the middle estimate sits 9 percentage points below what was measured; measured number inside the range.
By their numbers in this assay, from the lowest: compound 1; then compounds 3 and 2 (each within the scatter of the next).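

The step of a number 6 percentage points lower from compound 2 to compound 3 (within the scatter) shows that in this assay this position does not depend on 1H-indol-2-yl for a high number. 4-Cyanophenyl has one aromatic ring and no hydrogen-bond donor, yet it also stands clear of the bromopyrrole, with a number 27 percentage points higher from compound 1 to compound 3 (beyond the scatter). Nothing available explains why these groups give these numbers. From the compounds shown here alone, it stays open whether the bromine or the pyrrole ring of 4-bromo-1H-pyrrol-2-yl goes with the low number of compound 1. Going by these compounds, how an amine or a carboxylic acid on this carbonyl carbon would behave also stays open.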